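The source may report more compounds than this note shows. Statements on the series, on what has been measured and on what is new or still open speak of the compounds shown alone.

Measured compounds:
compound 1 `COc1ccc(N/C=C\C(=O)c2cn(-c3ccccc3)nc2-c2ccc(Cl)cc2)cc1` — 30800 nM
compound 2 `COc1cc(-c2nn(-c3ccccc3)cc2C(=O)/C=C\Nc2ccc(C(F)(F)F)cc2)cc(OC)c1OC` — > 50000 nM

In an ADME assay on HaCaT cells (Homo sapiens) for antiproliferative activity, read by MTT assay, with a stated time of 48 h (on this read-out lower numbers stand for stronger inhibition and higher numbers for weaker inhibition), compound 1 gives 30800 nM and so sits well into weak territory. Compound 2 gives > 50000 nM, which is a limit of the assay rather than a number, so its true value is known only as lying beyond that point; the limit of > 50000 nM in this assay, at which 1 of the 2 values shown sits, marks where it stands. Compound 3 `COc1ccc(N/C=C\C(=O)c2cn(-c3ccccc3)nc2-c2cc(OC)c(OC)c(OC)c2)cc1` has not been measured. It keeps the whole of compound 2 except at one place, where methoxy in place of trifluoromethyl on an aromatic carbon — methoxy in place of trifluoromethyl on an aromatic carbon. Among the measured compounds shown here, no comparable pair has been measured, so no step can be read off; the two values seen, one a plain number and one a limit, both point to weak activity throughout. Compound 3 is therefore expected to show an at least 1.2-fold lower number from compound 2 to compound 3 (0.09 log units; that floor lies within the scatter) as its step, that is, no shift beyond the scatter and a fair chance of a limit again. The estimate for compound 3 is 40000 nM, within 15000 nM to 100000 nM.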

Compound 3, half-maximal inhibitory concentration: > 50000 nM
Compound 3 ended at the assay's limit (the forecaster's own chance of this, stated with the estimate: 50%); middle value at least 1.2-fold (0.09 log units) away from the limit.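

In this assay, compound 3 joins compound 2 at a limit of the assay, so with either methoxy or trifluoromethyl on this aromatic carbon, para to a large group, no plain number is obtained: the limit of > 50000 nM in this assay, at which 2 of the 3 values shown sit. The step between these two compounds cannot be read, and the swap is shown only to leave both at the limit. With 3,4,5-trimethoxyphenyl in place of 4-chlorophenyl, the comparison gives an at least 1.6-fold higher number from compound 1 to compound 3 (0.21 log units; that floor lies within the scatter), so this change is not shown to go beyond the scatter.

Going by these compounds, how far compound 2 and compound 3 truly lie past the limit remains open. Also open, on these data alone, is whether an amine or a carboxylic acid on this aromatic carbon would bring a value back into the measurable range.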